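The source may report more compounds than this note shows. Statements on the series, on what has been measured and on what is new or still open speak of the compounds shown alone.

Measured so far in an assay on microsomes from intestinal mucosa for inhibition of acyl-CoA:cholesterol acyltransferase (Oryctolagus cuniculus); on this read-out lower numbers stand for stronger inhibition and higher numbers for weaker inhibition:

compound 1 `CCCCCCCC/C=C\CCCCCCCCNC(=O)Nc1c(C)cccc1Cl` — 180 nM
compound 2 `CCCCCCCC/C=C\CCCCCCCCNC(=O)Nc1c(CC)cccc1C(C)C` — 37 nM
compound 3 `CCCCCCCCCCCCCCNC(=O)Nc1c(C)cccc1Cl` — 70 nM

Two single changes connect these. The cores of compound 1 and compound 2 differ by 2-ethyl-6-isopropylphenyl in place of 2-chloro-6-methylphenyl on an amide-type nitrogen, which gave a 4.9-fold lower number from compound 1 to compound 2 (0.69 log units; beyond the scatter). The chain change hexyl in place of dec-1-en-1-yl on a saturated chain carbon, eight bonds along the chain from an amide-type nitrogen gave a 2.6-fold lower number from compound 1 to compound 3 (0.41 log units; beyond the scatter). Among the compounds with values here, no step is computed between compound 2 and compound 3; their two values lie within the scatter of each other, so nothing is read from their order.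

Compound 4 `CCCCCCCCCCCCCCNC(=O)Nc1c(CC)cccc1C(C)C` is not yet measured. It stands to compound 2 as compound 3 stands to compound 1: hexyl in place of dec-1-en-1-yl on a saturated chain carbon, eight bonds along the chain from an amide-type nitrogen. The place reads word for word the same as in the earlier pair, so this is the same change, now made on the other core. That change has been seen once, on the core of compound 1, and gave a modest step. Because the same change gave a 2.6-fold lower number from compound 1 to compound 3 (0.41 log units; beyond the scatter), the expected step is a 2.6-fold lower number from compound 2 to compound 4 (0.42 log units; beyond the scatter). Compound 4 is thus estimated at 14 nM, with a likely range of 6 nM to 35 nM.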

Compound 4, half-maximal inhibitory concentration: 18 nM
Compound 4: middle estimate off by 1.3-fold (0.11 log units), on the low side; measured number inside the range.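

In this assay, hexyl in place of dec-1-en-1-yl on the core of compound 2 gave a 2.1-fold lower number from compound 2 to compound 4 (0.31 log units; beyond the scatter), and the change carries from one core to the other in the same direction and at a matching size: the same change on two cores in this assay, a 2.6-fold lower number (0.41 log units; beyond the scatter) from compound 1 to compound 3 and a 2.1-fold lower number (0.31 log units; beyond the scatter) from compound 2 to compound 4, 1.3-fold (0.10 log units) apart, within the scatter of two such steps
Within the data shown here, this agreement rests on only two cores and one assay, so it supports additive treatment of the chain and the aryl change within these four compounds, not across the series as a whole. The change also removes the double bond and shortens the chain in a single step, so these compounds do not show which of the two accounts for the lower numbers, or why either would.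

A saturated decyl group in the same place, on a saturated chain carbon, eight bonds along the chain from an amide-type nitrogen, would separate those two parts of the change. Also open, going by these compounds, is whether the step holds for a longer chain, or for a chain carrying an amine or a carboxylic acid.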